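The source may hold more compounds than are shown below. What is called first, only, known or untested is meant among the compounds shown, and "the series" means these compounds.

Compound 1 `O=C(Nc1nc2ccc(Cl)cc2s1)c1cn(-c2ccccc2)nc1-c1ccc(Cl)cc1`: 5870 nM in a functional assay on U-87MG ATCC cells for cytotoxicity against U-87 MG (Homo sapiens), read by MTT assay, with a stated time of 72 h; a higher number here means a weaker inhibitor, a lower number a stronger inhibitor
Compound 2 `COc1ccc(-c2nn(-c3ccccc3)cc2C(=O)Nc2nc3ccccc3s2)cc1`: 11500 nM in this assay

Compound 2 has the higher of the two numbers, but its value and that of compound 1 lie within the scatter of each other, so no order between them is read. Going by the values given here, no single-point step between measured compounds is available. Compound 3 `COc1ccc(-c2nn(-c3ccccc3)cc2C(=O)Nc2nc3ccc(Cl)cc3s2)cc1` differs from compound 2 by chloro in place of hydrogen on an aromatic carbon. With no measured step of this kind in the series, the expected step is a 1.4-fold lower number from compound 2 to compound 3 (0.16 log units; within the scatter), nothing beyond the scatter. Compound 3 is estimated at 8000 nM, with a range of 3000 nM to 22000 nM.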

Compound 3, half-maximal inhibitory concentration: 8710 nM
For compound 3 the middle estimate is 1.1-fold (0.04 log units) below the measured one, and the stated range covers the measured number.
By their numbers in this assay, from the lowest: compounds 1, 3 and 2 (each within the scatter of the next).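

In this assay 6-chloro-1,3-benzothiazol-2-yl in place of 1,3-benzothiazol-2-yl gives a 1.3-fold lower number from compound 2 to compound 3 (0.12 log units; within the scatter) and so shows no readable effect of chloro at this aromatic carbon. Methoxy in place of chloro on an aromatic carbon gives a 1.5-fold higher number from compound 1 to compound 3 (0.17 log units; within the scatter) and likewise leaves no order between the two compounds. No measured evidence bears on either step.

From the compounds shown here alone, whether an amine or a carboxylic acid on this aromatic carbon would give a step beyond the scatter remains open. Also open, going by these compounds, is whether a longer chain than methoxy would do so.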